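Swapping a methoxycarbonyl for a sulfamoyl on the aniline

The source may hold more compounds than are shown below. What is called first, only, known or untested is meant among the compounds shown, and "the series" means these compounds.

Compound 1 `COC(=O)c1ccc(NC2=CC(=O)c3ncncc3C2=O)cc1` was tested in a functional assay on PANC-1 cells (Homo sapiens) for cytotoxicity, read by MTT assay, with a stated time of 72 h (a lower number here means a stronger inhibitor, a higher number a weaker inhibitor), where compound 1 gives 1100 nM. Compound 2 `O=C1C(NCc2ccc(F)cc2)=CC(=O)c2ncncc21` gives 1000 nM in this assay, so the two compounds stand at the same level, their gap within the usual scatter. Compound 3 `NS(=O)(=O)c1ccc(NC2=CC(=O)c3ncncc3C2=O)cc1` keeps the shared core of compound 1 and differs only in sulfamoyl in place of methoxycarbonyl on an aromatic carbon. Among the measured compounds shown here, no measured pair shows this change, so the step of a 1.2-fold higher number from compound 1 to compound 3 (0.07 log units; within the scatter) in this assay is expected to be small, in neither direction beyond the scatter. Compound 3 is estimated at 1300 nM, within 500 nM to 3500 nM.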

Compound 3, half-maximal inhibitory concentration: > 10000 nM
Compound 3 gave a limit, no number; the forecaster's own chance of this, stated with the estimate: 5%; at least 7.6-fold (0.88 log units) between middle value and limit.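

At this position, on an aromatic carbon para to a large group, the two groups are not interchangeable: sulfamoyl in place of methoxycarbonyl gives, in this assay, an at least 9.0-fold higher number from compound 1 to compound 3 (0.95 log units; beyond the scatter). Among the compounds shown here, this is the first single-place step, and it shows that this position responds to the identity of its group even though the heavy-atom count stays the same. The reading for compound 3 is a limit of the assay, not a number: the limit of > 10000 nM in this assay, at which 1 of the 3 values shown sits.

As far as these compounds go, whether a carboxylic acid or an amine at this position would stand nearer compound 1 or compound 3 stays open. The compounds shown also do not tell which part of the sulfamoyl goes with the step.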